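The compounds below may be only part of what the source reports. "The series", "measured", "known", "first", "only" and "open" are said of these compounds alone.

Compound 1 `CCn1cc(-c2ccc(Cl)cc2)c(=O)c2cc(F)c(N3CCNCC3)cc21`: 14600 nM
Compound 2 `CCn1cc(-c2ccc(OC)cc2)c(=O)c2cc(F)c(N3CCNCC3)cc21`: 46100 nM

In a functional assay on BGC-823 cells (Homo sapiens) for antiproliferative activity, read by MTT assay, with a stated time of 48 h (a lower number here means a stronger inhibitor, a higher number a weaker inhibitor), compound 2 has the higher of the two numbers, at 46100 nM, which makes it the weaker inhibitor of the pair. For the measured compounds named here, the only measured step is a 3.2-fold higher number from compound 1 to compound 2 (0.50 log units; beyond the scatter), and it swaps chloro for methoxy on an aromatic carbon. Compound 3 `COc1ccc(-c2cn(C3CC3)c3cc(N4CCNCC4)c(F)cc3c2=O)cc1` keeps the 4-methoxyphenyl group and differs from compound 2 at another place: cyclopropyl in place of ethyl on an aromatic nitrogen. Going by the values given here, no measured step changes the group on that aromatic nitrogen, so none bears on it directly, and no step beyond the scatter is expected. The expected change is a 1.2-fold lower number from compound 2 to compound 3 (0.06 log units; within the scatter). Compound 3 is estimated at 40000 nM, within a range of 15000 nM to 100000 nM.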

Compound 3, half-maximal inhibitory concentration: 18900 nM
Compound 3: the middle estimate sits 2.1-fold (0.33 log units) above what was measured; the range from low to high includes it.
By their numbers in this assay, from the lowest: compounds 1 and 3 (each within the scatter of the next); then compound 2.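

In this assay the group on the aromatic nitrogen turns out to affect the number, since cyclopropyl in place of ethyl gives a 2.4-fold lower number from compound 2 to compound 3 (0.39 log units; beyond the scatter). With the 4-methoxyphenyl group held fixed, cyclopropyl therefore gives the stronger inhibitor of this pair. Nothing shown explains why this change has this effect. From the compounds shown here alone, it remains open whether the same change would have a similar effect in compounds carrying chloro instead of methoxy. Going by these compounds, it is also open how a longer chain, such as n-butyl, or a benzyl group would behave on that nitrogen.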